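The compounds below may be only part of what the source reports. "The series", "measured", "known", "first", "only" and "open" are said of these compounds alone.

Of the compounds shown here, three have so far been measured in a functional assay on CHO cells for agonist activity at prostaglandin F2-alpha receptor (Homo sapiens), read by fluorescence and calcium flux; a lower number here means that less compound is needed, a higher number that more compound is needed for the effect. Compound 1 `O=C(O)CC[C@@H]1CC[C@@H]2[C@@H](/C=C/[C@@H](O)COc3ccccc3)[C@H](O)C[C@@H]2OC1` gives 1000 nM. Compound 2 `O=C(O)CCC[C@@H]1CC[C@@H]2[C@@H](/C=C/[C@@H](O)COc3ccccc3)[C@H](O)C[C@@H]2OC1` gives 280 nM, and compound 3 `O=C(O)CCC[C@H]1CC[C@@H]2[C@@H](/C=C/[C@@H](O)COc3ccccc3)[C@H](O)C[C@@H]2OC1` gives 28 nM. Compound 2 thus stands second highest of the three numbers: lengthening the acid chain by one carbon gave a 3.6-fold lower number from compound 1 to compound 2 (0.55 log units; beyond the scatter), and the further step a 10-fold lower number from compound 2 to compound 3 (1.00 log units; beyond the scatter) rests on (the fact that compounds 2 and 3 differ only in the configuration as drawn), the two compounds being otherwise identical.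

Compound 4 `O=C(O)CCCC[C@@H]1CC[C@@H]2[C@@H](/C=C/[C@@H](O)COc3ccccc3)[C@H](O)C[C@@H]2OC1` takes the chain of compound 2 one carbon further: carboxymethyl in place of carboxy on a saturated chain carbon, three bonds along the chain from a saturated ring carbon. Among the compounds with values here, the only measured step that bears on this change is the earlier lengthening of the same chain, which gave a 3.6-fold lower number from compound 1 to compound 2 (0.55 log units; beyond the scatter). Whether a second lengthening repeats that gain is not settled by the numbers at hand; a smaller step in the same direction, a 1.4-fold lower number from compound 2 to compound 4 (0.15 log units; within the scatter), is the expectation. Compound 4 is therefore estimated to give about 200 nM in this assay, with a likely range from 60 nM to 700 nM.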

Compound 4, half-maximal effective concentration: 110 nM
Estimate against measurement, compound 4: 1.8-fold (0.26 log units) above; the measured number falls inside the stated range.
By their numbers in this assay, from the lowest: compound 3; then compound 4; then compound 2; then compound 1.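

The gain from lengthening the acid chain did not end with the first added carbon: in this assay, the 4-carboxybutyl chain brings a 2.5-fold lower number from compound 2 to compound 4 (0.41 log units; beyond the scatter), so a second lengthening moves the number in the same direction as the first. Over the whole span, the chain change gives a 9.1-fold lower number from compound 1 to compound 4 (0.96 log units; beyond the scatter), and none of the three compounds in this chain series goes against that order. Nothing at hand gives a reason for this trend.

On these data alone, whether a still longer chain, such as 5-carboxypentyl, would lower the number further or raise it again remains open. Also open, as far as these compounds go, is how the 4-carboxybutyl chain would behave with the configuration drawn in compound 3, which gives 28 nM, the lowest number so far.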